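Swapping chloro for methoxy on a shared core

The source may hold more compounds than are shown below. What is called first, only, known or untested is meant among the compounds shown, and "the series" means these compounds.

Of the compounds shown here, three sharing one core have been tested in a toxicity assay on THP-1 cells (Homo sapiens) for cytotoxicity, read by MTT assay, with a stated time of 48 h; a higher number here means a weaker inhibitor of growth, a lower number a stronger inhibitor of growth. Compound 1, `CCOc1ccc2nc(Cl)c(/C=C3\SC(=S)NC3=O)cc2c1`, carries an ethoxy group on an aromatic carbon. In this assay compound 1 reaches only > 100 ug/mL, which is a limit of the assay and not a number. Compound 2, `O=C1NC(=S)S/C1=C\c1cc2cc(Cl)ccc2nc1Cl`, carries chloro in place of that ethoxy. In this assay compound 2 likewise reaches only > 100 ug/mL, again a limit rather than a number. Compound 3, `Cc1cccc2cc(/C=C3\SC(=S)NC3=O)c(Cl)nc12`, carries a methyl group instead. In this assay compound 3 also stops at > 100 ug/mL, a limit as well. Compound 2 therefore stands at the limit together with both other compounds, and the step that the two limits leave unreadable from compound 1 to compound 2 cannot be given a size, since both of its ends are limits.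

Compound 4, `COc1ccc2nc(Cl)c(/C=C3\SC(=S)NC3=O)cc2c1`, differs from compound 2 by methoxy in place of chloro on an aromatic carbon. Among the compounds with values here, the only measured step touching this place is a step that the two limits leave unreadable from compound 1 to compound 2, which yields no readable size. What the data do show is the limit of > 100 ug/mL in this assay, at which 3 of the 3 values shown sit. On that basis no step beyond the scatter is expected: the step that the limit leaves unreadable from compound 2 to compound 4 is estimated to be essentially none. Within the data shown here, compound 4 is accordingly expected to give about 150 ug/mL, within 60 ug/mL to 400 ug/mL, and most probably only a limit once more, since the limit of > 100 ug/mL in this assay, at which 3 of the 3 values shown sit, describes every compound measured so far.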

Compound 4, concentration for 50% growth inhibition: > 100 ug/mL
Compound 4 ended at the assay's limit; the forecaster's own chance of this, stated with the estimate: 80%; the middle value is on the limit's open side.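

No new step can be read, since compound 4, like compound 1 and compound 2, gives only a limit of the assay and not a number: the limit of > 100 ug/mL in this assay, at which 4 of the 4 values shown sit.

The compounds shown leave open how strongly any of them inhibits growth in this assay and whether swapping chloro, methoxy or ethoxy on the shared core changes that at all.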